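Series notes: from compound 2 to compound 3

A few compounds are considered here, and "the series" means these few. Any claim that something is new, unique, unknown or untested is made for them only; others in the source may bear on it.

Of the compounds shown here, two have numbers so far. Compound 1 `CC1=CC[C@@H]([C@@](C)(O)CCCC(C)(C)NC(=S)NN)CC1` in a functional assay on OVCAR-3 cells (Homo sapiens) for cytotoxicity, read by sulforhodamine B assay (on this read-out higher numbers stand for weaker inhibition of growth and lower numbers for stronger inhibition of growth), gives 17200 nM. Compound 2 `CC1=CC[C@@H]([C@@](C)(O)CCCC(C)(C)NC(=S)N/N=C\c2ccc([N+](=O)[O-])cc2)CC1` in this assay gives 13400 nM; this is the lower of the two numbers, and its nearest neighbour is compound 1, whose number lies within the usual scatter of it, so no order between the two can be read. Among the measured compounds shown here, no step between measured compounds that differ in one place is available.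

Compound 3 `CC1=CC[C@@H]([C@@](C)(O)CCCC(C)(C)NC(=S)N/N=C\c2ccccc2Cl)CC1` has not been measured in this assay. Its difference from compound 2 is 2-chlorophenyl in place of 4-nitrophenyl on a carbon with a double bond to nitrogen. Compound 1 at 17200 nM and compound 2 at 13400 nM differ little from one another, and on that basis the aryl exchange is expected to give no step beyond the scatter. The step from compound 2 to compound 3 is estimated as a 1.0-fold lower number from compound 2 to compound 3 (0.01 log units; within the scatter). Compound 3 in this assay is expected to give about 13000 nM, within 5000 nM to 35000 nM.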

Compound 3, concentration for 50% growth inhibition: 42000 nM
Compound 3: middle estimate off by 3.2-fold (0.51 log units), on the low side, and the stated range ends below it.
By their numbers in this assay, from the lowest: compounds 2 and 1 (each within the scatter of the next); then compound 3.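

In this assay, among the compounds shown here, the group on the carbon with a double bond to nitrogen proves not to be indifferent: 2-chlorophenyl in place of 4-nitrophenyl gives a 3.1-fold higher number from compound 2 to compound 3 (0.50 log units; beyond the scatter) as a modest step, which the first pair of values could not show. Set against the free nitrogen end of compound 1, the group of 9 heavy atoms carrying the 2-chlorophenyl gives a 2.4-fold higher number from compound 1 to compound 3 (0.39 log units; beyond the scatter) and thus weaker inhibition of growth, whereas compound 2 stays within the scatter of compound 1. Nothing measured here accounts for either step.

The exchange removes the nitro group and brings in chlorine in one move, so the share of each remains unresolved. Where a plain phenyl or a saturated alkyl chain on this carbon would stand remains open.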